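The compounds below may be only part of what the source reports. "The series", "measured", "known", "first", "only" and "open" are said of these compounds alone.

Compound 1 `N#CC1=C(N)Oc2c(c3nc4ccccc4nc3c3ccccc23)C12C(=O)N(Cc1cnnn1-c1ccc(Br)cc1)c1ccccc12` carries 4-bromophenyl on the aromatic nitrogen of the shared core. In a functional assay on HepG2 cells (Homo sapiens) for antiproliferative activity, read by MTT assay, with a stated time of 48 h (on this read-out higher numbers stand for weaker inhibition and lower numbers for stronger inhibition), compound 1 gives only a limit of the assay, > 50000 nM. Compound 2 `N#CC1=C(N)Oc2c(c3nc4ccccc4nc3c3ccccc23)C12C(=O)N(Cc1cnnn1-c1cccc(S(N)(=O)=O)c1)c1ccccc12` carries 3-sulfamoylphenyl at that position instead; in this assay compound 2 gives 21500 nM. Among the compounds with values here, the single measured step, an at least 2.3-fold lower number from compound 1 to compound 2 (0.36 log units; beyond the scatter), starts from a limit, so its true size is open at the upper end. Within the data shown here, compound 2 therefore holds the only number in this assay; the remaining value is a limit, (the limit of > 50000 nM in this assay, at which 1 of the 2 values shown sits). Compound 3 `N#CC1=C(N)Oc2c(c3nc4ccccc4nc3c3ccccc23)C12C(=O)N(Cc1cnnn1-c1cc(Cl)ccc1Cl)c1ccccc12` differs from compound 2 by 2,5-dichlorophenyl in place of 3-sulfamoylphenyl on an aromatic nitrogen, returning to a halogenated phenyl as in compound 1. Among the measured compounds shown here, with that step as the sole guide, compound 3 is expected to move back toward weaker inhibition, a 2.3-fold higher number from compound 2 to compound 3 (0.37 log units; beyond the scatter), with a real chance that only a limit is reported. The estimate for compound 3 in this assay is 50000 nM, expected within 18000 nM to 140000 nM.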

Compound 3, half-maximal inhibitory concentration: > 50000 nM
Compound 3: a limit, no number (the forecaster's own chance of this, stated with the estimate: 55%); the middle value sits exactly at the limit.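

In this assay, replacing 3-sulfamoylphenyl with 2,5-dichlorophenyl on the aromatic nitrogen reverses the earlier gain, with an at least 2.3-fold higher number from compound 2 to compound 3 (0.36 log units; beyond the scatter). Within the data shown here, compound 1 and compound 3, the two halogenated phenyl compounds, both end at a limit rather than a number, leaving 3-sulfamoylphenyl as the only group here with a measured value: the limit of > 50000 nM in this assay, at which 2 of the 3 values shown sit. The two limits also leave the step between compound 1 and compound 3 unreadable, so the 4-bromophenyl and 2,5-dichlorophenyl groups cannot be ranked.

Going by these compounds, it remains open whether the measured value depends on the sulfonamide itself or merely on the absence of halogen, a question that an unsubstituted phenyl or a 3-carboxyphenyl group would address. On these data alone, the role of the substituent's ring position also remains open, and 4-sulfamoylphenyl would test it directly.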